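A few compounds are considered here, and "the series" means these few. Any claim that something is new, unique, unknown or untested is made for them only; others in the source may bear on it.

Compound 2, with the structure `COc1cc(-c2nnc(SCC(=O)c3ccccc3)n2N2C(=O)c3ccccc3C2=O)cc(OC)c1OC`, is one of two compounds whose cytotoxicity has been recorded in a functional assay on PC-3M cells (Homo sapiens) for cytotoxicity, read by MTT assay, with a stated time of 48 h; on this read-out lower numbers stand for stronger inhibition and higher numbers for weaker inhibition. In this assay compound 2 gives > 200000 nM, which is a limit of the assay rather than a number. Its neighbour compound 1, the structure `COc1cc(-c2nnc(SC)n2N2C(=O)c3ccccc3C2=O)cc(OC)c1OC`, gives in this assay > 200000 nM, also a limit. The step that the two limits leave unreadable from compound 1 to compound 2 therefore cannot be sized. Among the measured compounds shown here, the only evidence at hand is the limit of > 200000 nM in this assay, at which 2 of the 2 values shown sit. Compound 3 has the structure `COc1cc(-c2nnc(SCC(=O)c3ccc(F)cc3)n2N2C(=O)c3ccccc3C2=O)cc(OC)c1OC` and differs from compound 2 by fluoro in place of hydrogen on an aromatic carbon. For the measured compounds named here, no measured step resembles this change, and the single measured step is itself unreadable, so no direction can be drawn from it. Compound 3 is expected to stay at the same limit, the step of a number no higher from compound 2 to compound 3 (the limit leaves the size open) being expected to show nothing beyond the scatter. The estimate for compound 3 in this assay is 200000 nM, within 50000 nM to 800000 nM.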

Compound 3, half-maximal inhibitory concentration: > 200000 nM
Compound 3: no number, only a limit (the forecaster's own chance of this, stated with the estimate: 85%); the middle value lies on the limit itself.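

In this assay compound 3 gives > 200000 nM, which is a limit and not a number. Among the compounds shown here, no step among compound 1, compound 2 and compound 3 can therefore be read. The compounds shown leave open whether benzoyl or fluoro changes cytotoxicity at all, as all the evidence rests on one limit: the limit of > 200000 nM in this assay, at which 3 of the 3 values shown sit.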